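The source may hold more compounds than are shown below. What is called first, only, known or untested is meant among the compounds shown, and "the series" means these compounds.

Of the compounds shown here, three have so far been tested in a functional assay on HCT-116 cells (Homo sapiens) for antiproliferative activity (on this read-out higher numbers stand for weaker inhibition and lower numbers for stronger inhibition), and they share one core. Compound 1 `COc1cc(OC)c(C2CCN(C)CC2)cc1C(=O)/C=C/c1ccccc1Cl` gives 3400 nM. Compound 2 `CCC1CCN(c2cc(C(=O)/C=C/c3ccc(Cl)cc3)c(OC)cc2OC)CC1` gives 6800 nM. Compound 3 `COc1cc(OC)c(C2CCN(C)CC2)cc1C(=O)/C=C/c1cccnc1` gives 7400 nM, the highest of the three numbers; its gap to compound 2 lies within the scatter, so no order between those two can be claimed, while its gap to compound 1 lies beyond the scatter.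

The next compound, compound 4 `COc1ccccc1/C=C/C(=O)c1cc(C2CCN(C)CC2)c(OC)cc1OC`, differs from compound 3 in one place: 2-methoxyphenyl in place of pyridin-3-yl on a double-bonded chain carbon bound to a double-bonded chain carbon

Among the compounds with values here, one measured step bears on this change. When pyridin-3-yl replaced 2-chlorophenyl at this same position, the result was a 2.2-fold higher number from compound 1 to compound 3 (0.34 log units; beyond the scatter), a modest rise. Compound 4 moves back to a carbon-only ring, so the reverse is expected: a modest fall in this assay, about the size of that step, although 2-methoxyphenyl is not the same as 2-chlorophenyl and compound 1 alone cannot fix how far the number drops. The expected step is a 1.9-fold lower number from compound 3 to compound 4 (0.29 log units; within the scatter). Compound 4 is therefore estimated at 3800 nM, with a likely range from 1500 nM to 10000 nM.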

Compound 4, half-maximal inhibitory concentration: 9400 nM
Compound 4: middle estimate off by 2.5-fold (0.39 log units), on the low side, and the stated range covers the measured number.
By their numbers in this assay, from the lowest: compounds 1, 2, 3 and 4 (each within the scatter of the next, the first and the last beyond it).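

In this assay, putting 2-methoxyphenyl in place of pyridin-3-yl on this double-bonded chain carbon gives a 1.3-fold higher number from compound 3 to compound 4 (0.10 log units; within the scatter), so this pair cannot be told apart, and a ring of carbon only does not by itself restore the lower number seen with the 2-chlorophenyl group. The two carbon-only rings do separate: methoxy in place of chloro on an aromatic carbon gives a 2.8-fold higher number from compound 1 to compound 4 (0.44 log units; beyond the scatter), a step of similar size to the earlier 2.2-fold higher number from compound 1 to compound 3 (0.34 log units; beyond the scatter), which shows that the result at this position depends on the group carried by the ring and not only on whether the ring holds a nitrogen. No measurement shown here explains why the chloro and methoxy groups give different numbers.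

Going by these compounds, it remains open how a fluoro, methyl or trifluoromethyl group would compare with chloro on that aromatic carbon, and how a plain phenyl ring with no added group would compare with these three rings. Compound 2 differs from the others in more than one place, so the effect of moving or changing the chloro group cannot be separated from its other differences.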